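Ether-chain variants on a shared aminoquinoline-type core

This account rests on a few compounds, and the source may have more. Where it says the series, first, only, none or still open, it means among the compounds named here.

Compound 3 `CSCCOc1cccc2ccc(N)nc12` reaches only the limit > 2000 nM in an assay on cells with melanin-concentrating hormone receptor 1 (Homo sapiens) as the target, read by radioligand binding (on this read-out higher numbers stand for weaker inhibition and lower numbers for stronger inhibition), as noted in the limit of > 2000 nM in this assay, at which 2 of the 3 values shown sit. Compound 2 `CCCCOc1cccc2ccc(N)nc12` gives 789 nM in this assay, and the change an at least 2.5-fold higher number from compound 2 to compound 3 (0.40 log units; beyond the scatter) marks the move to compound 3. Compound 1 `CC#CCCOc1cccc2ccc(N)nc12` also sits at the limit > 2000 nM. The step that the two limits leave unreadable from compound 1 to compound 3 therefore stays unreadable, while an at least 2.5-fold lower number from compound 1 to compound 2 (0.40 log units; beyond the scatter) is readable.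

Compound 4 `CCOCC(C)Oc1cccc2ccc(N)nc12` carries the change (a group of 6 heavy atoms (5 carbon, 1 oxygen; no ring) in place of a group of 4 heavy atoms (3 carbon, 1 sulfur; no ring), on an oxygen on an aromatic ring). The two readable steps show that a chain with a heteroatom, as in compound 3, or an unsaturated chain, as in compound 1, reads weaker than the plain chain of compound 2; the entering group again places a heteroatom within the chain. Compound 4 is therefore expected to remain weak, with the step that the limit leaves unreadable from compound 3 to compound 4 estimated as small, and its value estimated at 3000 nM (range 800 nM to 12000 nM).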

Compound 4, half-maximal inhibitory concentration: 1070 nM
The estimate for compound 4 lay 2.8-fold (0.45 log units) above the measured number; low and high end bracket the measured number.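

In this assay, the step is a 1.4-fold higher number from compound 2 to compound 4 (0.13 log units; within the scatter), so a chain holding an oxygen can sit level with the all-carbon chain of compound 2, and a heteroatom in the chain does not by itself give the weak reading of compound 3. The other two steps, an at least 1.8-fold lower number from compound 3 to compound 4 (0.27 log units; that floor lies within the scatter) and an at least 1.8-fold lower number from compound 1 to compound 4 (0.27 log units; that floor lies within the scatter), give floors only, because compound 1 and compound 3 are limits: the limit of > 2000 nM in this assay, at which 2 of the 4 values shown sit.

Going by these compounds, whether an amine, a carboxylic acid or a longer all-carbon chain on this oxygen would give a lower number remains open. The shown compounds also do not separate the chain oxygen of compound 4 from its larger group size.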